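The compounds below may be only part of what the source reports. "The series", "measured", "known", "first", "only" and "open" are said of these compounds alone.

Compound 1 `Fc1ccc(-c2nn3c(NC4CCCC4)cccc3c2-c2ccncc2)cc1`: in an ADME assay on Vero cells (Chlorocebus sabaeus) for cytotoxicity (on this read-out higher numbers stand for lower toxicity in this test and lower numbers for higher toxicity in this test), compound 1 gives 20000 nM. Compound 2 `Nc1nc(-c2c(-c3ccc(F)cc3)nn3c(NC4CCCC4)cccc23)c[nH]1`: in this assay compound 2 gives "not determined" (no result reported). Compound 3 `Fc1ccc(-c2nn3c(NC4CCCC4)cccc3c2-c2ccco2)cc1`: in this assay compound 3 gives "not determined" (no result reported).

Within the data shown here, compound 3 therefore has no number of its own in this assay, and compound 2 is a second entry without a number, so the only figure to lean on is the one from compound 1. The new compound 4 `Fc1ccc(-c2nn3c(NC4CCCC4)cccc3c2-c2cccnc2)cc1` arises from compound 3 by one exchange: pyridin-3-yl in place of furan-2-yl on an aromatic carbon.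

Among the measured compounds shown here, because no measured pair shares this exact exchange, the size of the step in this assay cannot be read from the data; there is no basis to expect a shift in either direction beyond the usual scatter. For the measured compounds named here, compound 4 carries a six-membered ring with one nitrogen at the same place where compound 1 carries its own six-membered nitrogen ring, and compound 1 is the one compound with a number in this assay. On that ground, compound 4 is expected to land near 20000 nM in this assay, with a plausible range from 6000 nM to 50000 nM.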

Compound 4, half-maximal cytotoxic concentration: > 40000 nM
Compound 4: a limit, no number (the forecaster's own chance of this, stated with the estimate: 30%); middle value at least 2.0-fold (0.30 log units) away from the limit.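

Moving the ring nitrogen of the pyridine at this aromatic carbon, with pyridin-3-yl in place of pyridin-4-yl, gives an at least 2.0-fold higher number from compound 1 to compound 4 (0.30 log units; that floor lies within the scatter), so the two pyridines can now be compared in this assay, though that floor does not separate them beyond the usual scatter. In this test, compound 4 gives no sign that this shift of the nitrogen brings more toxicity, and its reading is a limit and not a number: the limit of > 40000 nM in this assay, at which 1 of the 4 values shown sits. Steps involving compound 2 or compound 3 cannot be read, so the exchange of furan-2-yl for pyridin-3-yl has no measured size.

From the compounds shown here alone, how far the true value of compound 4 lies from that of compound 1 stays open. So does the reading at this place for pyridin-2-yl, a carboxylic acid or a saturated amine such as piperidine.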